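Swapping chloro for methyl on compound 3

A few compounds are considered here, and "the series" means these few. Any claim that something is new, unique, unknown or untested is made for them only; others in the source may bear on it.

Three related compounds have been measured in a functional assay on HeLa cells (Homo sapiens) for antiproliferative activity, read by MTT assay, with a stated time of 48 h; a higher number here means a weaker inhibitor, a lower number a stronger inhibitor. Compound 1 (`Cc1ccc2nc(NC(c3cn(-c4ccccc4)nc3-c3cccc(Cl)c3)c3c(O)ccc4ccccc34)sc2c1`) gives 9430 nM, and compound 2 (`COc1ccc2nc(NC(c3cn(-c4ccccc4)nc3-c3ccc([N+](=O)[O-])cc3)c3c(O)ccc4ccccc34)sc2c1`) gives 5540 nM. Compound 3 (`O=[N+]([O-])c1ccc(-c2nn(-c3ccccc3)cc2C(Nc2nc3ccc(Cl)cc3s2)c2c(O)ccc3ccccc23)cc1`) gives 13400 nM, a value within the usual scatter of that of compound 1 and clearly separated only from that of compound 2.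

Compound 4 (`Cc1ccc2nc(NC(c3cn(-c4ccccc4)nc3-c3ccc([N+](=O)[O-])cc3)c3c(O)ccc4ccccc34)sc2c1`) differs from compound 3 in one place: 6-chloro-1,3-benzothiazol-2-yl becomes 6-methyl-1,3-benzothiazol-2-yl (methyl in place of chloro on an aromatic carbon). One measured step changes the same position, with chloro in place of methoxy: a 2.4-fold higher number from compound 2 to compound 3 (0.38 log units; beyond the scatter). This modest step shows chloro with the higher number in that pair. For the measured compounds named here, no measured pair exchanges chloro for methyl directly, and compound 1 also differs from compound 3 elsewhere, so the evidence is thin. A small move toward a lower number seems likely, probably not beyond the scatter. The expected change is a 1.7-fold lower number from compound 3 to compound 4 (0.22 log units; within the scatter) in this assay. For compound 4 the estimated value is 8000 nM, with an expected range from 4000 nM to 15000 nM.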

Compound 4, half-maximal inhibitory concentration: 7040 nM
Compound 4: the middle estimate sits 1.1-fold (0.06 log units) above what was measured, and the stated range covers the measured number.
By their numbers in this assay, from the lowest: compounds 2, 4, 1 and 3 (each within the scatter of the next, the first and the last beyond it).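

In this assay, methyl in place of chloro gives a 1.9-fold lower number from compound 3 to compound 4 (0.28 log units; within the scatter) and methyl in place of methoxy gives a 1.3-fold higher number from compound 2 to compound 4 (0.10 log units; within the scatter) so methyl sits within the scatter of both other groups at this position, even though the chloro and methoxy compounds are clearly separated from each other. With the 6-methyl-1,3-benzothiazol-2-yl group held fixed, the exchange elsewhere on the molecule gives a 1.3-fold lower number from compound 1 to compound 4 (0.13 log units; within the scatter) and so also stays within the scatter. Nothing available here explains why these groups compare as they do.

On these data alone, whether an amine, a carboxylic acid or a longer chain such as propyl at this position would move the number further than these three groups do remains open. So does whether the same comparison among methyl, chloro and methoxy would hold with 3-chlorophenyl in place of 4-nitrophenyl.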